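The source may report more compounds than this note shows. Statements on the series, on what has been measured and on what is new or still open speak of the compounds shown alone.

Measured so far in an ADME assay on L02 cells (Homo sapiens) for cytotoxicity, read by MTT assay, with a stated time of 48 h; on this read-out lower numbers stand for stronger inhibition and higher numbers for weaker inhibition:
compound 2 `COc1cc2ccc(=O)oc2cc1OCCCCCOc1c[n+]([O-])on1` gives 8860 nM
compound 1 `COc1cc2ccc(=O)oc2cc1OCCCCOc1no[n+]([O-])c1S(=O)(=O)c1ccccc1` gives 9330 nM

Compound 2 stands at the lower of the two numbers in this assay; compound 1 sits only a little higher, and that gap lies within the scatter, so the two compounds cannot be told apart on cytotoxicity. Among the measured compounds shown here, no step between two measured compounds that differ in one place is available, so there is no measured scale for a single change.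

Compound 3 `COc1cc2ccc(=O)oc2cc1OCCCCCCOc1c[n+]([O-])on1` has not yet been measured in this assay. Set against compound 2, the change is a group of 8 heavy atoms (3 carbon, 2 nitrogen, 3 oxygen; one five-membered aromatic ring with 3 hetero atoms) in place of a group of 7 heavy atoms (2 carbon, 2 nitrogen, 3 oxygen; one five-membered aromatic ring with 3 hetero atoms), on a saturated chain carbon, five bonds along the chain from an oxygen on an aromatic ring. The ring that leaves and the ring that enters are alike in their count of hetero atoms and acceptors; what enters is the larger group by the count shown, on the saturated chain.

For the measured compounds named here, with no measured step to lean on, and with compound 1 and compound 2 already within the scatter of each other, the expected step from compound 2 to compound 3 is a 1.0-fold lower number from compound 2 to compound 3 (0.02 log units; within the scatter), that is, none beyond the scatter. Compound 3 is thus estimated at 8500 nM, within 4200 nM to 17000 nM.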

Compound 3, half-maximal inhibitory concentration: 12400 nM
Compound 3: the middle estimate sits 1.5-fold (0.16 log units) below what was measured; measured number inside the range.
By their numbers in this assay, from the lowest: compounds 2, 1 and 3 (each within the scatter of the next).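

In this assay, the series now has its first measured step for one change at this position: a 1.4-fold higher number from compound 2 to compound 3 (0.15 log units; within the scatter), for a group of 8 heavy atoms (3 carbon, 2 nitrogen, 3 oxygen; one five-membered aromatic ring with 3 hetero atoms) in place of a group of 7 heavy atoms (2 carbon, 2 nitrogen, 3 oxygen; one five-membered aromatic ring with 3 hetero atoms), on a saturated chain carbon, five bonds along the chain from an oxygen on an aromatic ring. Compound 1 and compound 2 offered no such scale, and this change, which adds one heavy atom to the group, stays inside the scatter on this read-out. Nothing measured on these compounds bears on the size of this step.

Still open, as far as these compounds go, is whether a longer chain, or an amine or a carboxylic acid in place of the ring at this position, would give a step beyond the scatter. Among the compounds shown here, a single step also fixes no trend along the chain, and compound 1 offers no second step to set beside this one.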